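This account rests on a few compounds, and the source may have more. Where it says the series, first, only, none or still open, it means among the compounds named here.

Among the measured compounds shown here, compound 1 `COc1ccc(-c2c(-c3ccc(OC)cc3)n(Cc3ccccc3)c3ncn([C@@H]4CCCC[C@H]4O)c(=N)c23)cc1` is one of three compounds measured in an ADME assay for permeability, using PAMPA, with a stated time of 30 min, at pH 7.4; on this read-out higher numbers stand for higher permeability and lower numbers for lower permeability. For compound 1 the read-out in this assay is only a limit, > 1000 10^-6 cm/s, and not a number. Compound 2 `N=c1c2c(-c3ccccc3)c(-c3ccccc3)n(Cc3ccccc3)c2ncn1CCCN1CCN(c2ccccc2)CC1` likewise reaches only a limit in this assay, at > 1000 10^-6 cm/s. Compound 3 `N=c1c2c(-c3ccccc3)c(-c3ccccc3)n(Cc3ccccc3)c2ncn1CCNc1ccncc1` gives a number in this assay, 445 10^-6 cm/s. Two of the three values thus sit at the limit of > 1000 10^-6 cm/s in this assay, at which 2 of the 3 values shown sit. Compound 4 `COc1ccc(-c2c(-c3ccc(OC)cc3)n(Cc3ccccc3)c3ncn(CCCO)c(=N)c23)cc1` has not yet been measured; it differs from compound 1 in one place (3-hydroxypropyl in place of 2-hydroxycyclohexyl on an aromatic nitrogen). For the measured compounds named here, no measured pair shows a step of this kind, so the step of an at least 1.4-fold lower number from compound 1 to compound 4 (0.15 log units; that floor lies within the scatter) is expected to be small and, if anything, downward. Compound 4 is expected to give about 700 10^-6 cm/s, with a range from 300 10^-6 cm/s to 1300 10^-6 cm/s.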

Compound 4, apparent permeability: > 1000 10^-6 cm/s
Compound 4 was reported as a limit (the forecaster's own chance of this, stated with the estimate: 40%); middle value at least 1.4-fold (0.15 log units) away from the limit.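

No step can be read from compound 1 to compound 4, because both results are limits and not numbers: the limit of > 1000 10^-6 cm/s in this assay, at which 3 of the 4 values shown sit.

The compounds shown leave open whether 3-hydroxypropyl in place of 2-hydroxycyclohexyl changes the read-out in this assay at all.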